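A few compounds are considered here, and "the series" means these few. Any claim that something is new, unique, unknown or untested is made for them only; others in the source may bear on it.

In a physicochemical assay for solubility, measured as kinetic solubility (a lower number here means a less soluble compound, a higher number a more soluble compound), compound 1 `CC(=O)Nc1cc(-c2ccc(N(C)C(=O)c3c(F)cccc3Cl)c(N3CC4CC4C3)c2)n(C(C)C)n1` gives 2.1 ug/mL, the second highest of three numbers, while compound 2 `CC(=O)Nc1cc(-c2ccc(N(C)C(=O)c3c(Cl)cccc3Cl)c(N3CC4CC4C3)c2)n(C(C)C)n1` gives 0.8 ug/mL and compound 3 `CC(=O)Nc1cc(-c2ccc(N(C)C(=O)c3c(C)cccc3F)c(N3CC4CC4C3)c2)n(C(C)C)n1` gives 17 ug/mL. Compound 4 `CC(=O)Nc1cc(-c2ccc(N(C)C(=O)c3c(F)cccc3Cl)c(N3CC4CC4C3)c2)n(CC(C)(C)C)n1` has neopentyl in place of isopropyl on an aromatic nitrogen. Within the data shown here, no measured step touches that place. The measured steps, a 2.6-fold lower number from compound 1 to compound 2 (0.42 log units; beyond the scatter), an 8.1-fold higher number from compound 1 to compound 3 (0.91 log units; beyond the scatter) and a 21-fold higher number from compound 2 to compound 3 (1.33 log units; beyond the scatter), show only how far this assay moves with changes elsewhere in these compounds. Among the measured compounds shown here, the data hold no direct precedent, so the expectation stays close to compound 1 at 2.1 ug/mL, leaning slightly lower and not clearly beyond the scatter. The expected change is a 1.6-fold lower number from compound 1 to compound 4 (0.21 log units; within the scatter). Compound 4 is estimated at 1.3 ug/mL, with an expected range from 0.4 ug/mL to 4 ug/mL.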

Compound 4, solubility: 0.8 ug/mL
Estimate against measurement, compound 4: 1.6-fold (0.21 log units) above, and the stated range covers the measured number.
By their numbers in this assay, from the lowest: compounds 2 and 4 (each within the scatter of the next); then compound 1; then compound 3.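

The aromatic nitrogen of the five-membered ring is a place that moves the read-out in this assay: with neopentyl in place of isopropyl there is a 2.6-fold lower number from compound 1 to compound 4 (0.42 log units; beyond the scatter). Among these compounds, this is the first measured change at this position, and it shows that the larger of these two carbon chains gives the lower number. Nothing available explains the drop.

Going by these compounds, what a chain ending in an amine or a carboxylic acid would give on this nitrogen remains open. So does whether the same swap would give a similar step with the 2-fluoro-6-methylphenyl group of compound 3.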